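Swapping an amine for a plain chain on cytotoxicity

A few compounds are considered here, and "the series" means these few. Any claim that something is new, unique, unknown or untested is made for them only; others in the source may bear on it.

Compound 1 `Cc1ccccc1-c1nn(-c2ccc(F)cc2F)cc1CNCCN1CCCCC1` and compound 2 `Cc1ccccc1-c1nn(-c2ccc(F)cc2F)cc1CNCCN(C)C` share one core. In an ADME assay on Huh-7 cells (Homo sapiens) for cytotoxicity (a higher number here means that more compound is tolerated, a lower number that less compound is tolerated), compound 1 gives only a limit, > 20000 nM. In this assay compound 2 likewise gives only a limit, > 20000 nM. The step that the two limits leave unreadable from compound 1 to compound 2 cannot be read, as both values sit at the limit of > 20000 nM in this assay, at which 2 of the 2 values shown sit. Compound 3 `CCCCCNCc1cn(-c2ccc(F)cc2F)nc1-c1ccccc1C` differs from compound 2 by propyl in place of dimethylamino on a saturated chain carbon, two bonds along the chain from an amine nitrogen. Among the measured compounds shown here, no measured step gives a readable size for such a change, so nothing beyond the scatter can be foreseen. Compound 3 is expected to reach 30000 nM (range 10000 nM to 100000 nM) in this assay. That expectation amounts to the estimated step that the limit leaves unreadable from compound 2 to compound 3.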

Compound 3, half-maximal cytotoxic concentration: 17000 nM
The estimate for compound 3 lay 1.8-fold (0.25 log units) above the measured number; low and high end bracket the measured number.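

Among the compounds shown here, with propyl in place of dimethylamino, the chain loses its second amine, and compound 3 gives the first true number in this assay, 17000 nM. Against the earlier limits, this reads as an at least 1.1-fold lower number from compound 2 to compound 3 (0.07 log units; that floor lies within the scatter), and as an at least 1.1-fold lower number from compound 1 to compound 3 (0.07 log units; that floor lies within the scatter). Each printed floor lies within the scatter, yet the real steps could be larger.

Going by these compounds, the true size of either step stays open. Also open, on these data alone, is what a longer chain or a carboxylic acid at this chain end would give in this assay.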